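Ring methyl on the fused ring of compound 1

The source may hold more compounds than are shown below. What is called first, only, known or untested is meant among the compounds shown, and "the series" means these compounds.

Compound 1 `O=c1oc(Nc2ccccc2I)nc2ccccc12` is the reference of this small set. In an assay on isolated protein for inhibition of complement C1r subcomponent (Homo sapiens) (a higher number here means a weaker inhibitor, a lower number a stronger inhibitor), compound 1 gives 3500 nM, the highest number of the three measured compounds. Compound 2 `CN(c1nc2ccccc2c(=O)o1)c1ccccc1I` gives 1400 nM, and compound 3 `O=c1oc(Nc2ccccc2I)nc2cc(Cl)ccc12` gives 700 nM. Both measured steps lead away from compound 1 toward lower numbers: a 2.5-fold lower number from compound 1 to compound 2 (0.40 log units; beyond the scatter) and a 5.0-fold lower number from compound 1 to compound 3 (0.70 log units; beyond the scatter).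

Compound 4 `Cc1ccc2nc(Nc3ccccc3I)oc(=O)c2c1` differs from compound 1 in one place: methyl in place of hydrogen on an aromatic carbon.

Neither measured step is the same change. The step of a 2.5-fold lower number from compound 1 to compound 2 (0.40 log units; beyond the scatter) puts a methyl on the ring nitrogen rather than on an aromatic carbon. The step of a 5.0-fold lower number from compound 1 to compound 3 (0.70 log units; beyond the scatter) adds a group to the same fused carbocyclic ring, but a chloro, and at another place. What the two steps share is that each addition to compound 1 lowered the number in this assay, and nothing measured points to a rise. Going by the values given here, a modest drop is therefore expected for compound 4, kept smaller than the chloro step and with a wide range, as methyl on this carbon has no direct precedent here.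

For compound 4 the expected value in this assay is 1800 nM, within 700 nM to 4500 nM. The expected step is then a 1.9-fold lower number from compound 1 to compound 4 (0.29 log units; within the scatter).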

Compound 4, half-maximal inhibitory concentration: > 62500 nM
Compound 4 ended at the assay's limit (the forecaster's own chance of this, stated with the estimate: 5%); at least 34-fold (1.54 log units) between middle value and limit.
By their numbers in this assay, from the lowest: compounds 3 and 2 (each within the scatter of the next); then compound 1. At a limit, above all of these: compound 4.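

In this assay, going by these compounds alone, the methyl in place of hydrogen on an aromatic carbon gives an at least 17-fold higher number from compound 1 to compound 4 (1.25 log units; beyond the scatter), the first step in the set that raises the number. Additions to compound 1 therefore do not all act alike: a 2.5-fold lower number from compound 1 to compound 2 (0.40 log units; beyond the scatter) and a 5.0-fold lower number from compound 1 to compound 3 (0.70 log units; beyond the scatter) both lower it, and compound 4 goes against them, so a gain from a small group on the shared core does not carry over to this carbon, which is meta to a fused ring and para to a fused ring. Compound 4 stands at a limit of this assay with > 62500 nM, which is a limit and not a number: the limit of > 62500 nM in this assay, at which 1 of the 4 values shown sits.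

The compounds shown leave open whether this carbon turns against any added group or against methyl alone, and a fluoro, a methoxy or an amine in the same place would separate those two readings. They also leave open whether methyl on the carbon that carries the chloro in compound 3 would lower the number as the chloro does, or would raise it as the methyl of compound 4 does.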